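The compounds below may be only part of what the source reports. "The series", "measured", "known", "first", "only" and "open" are said of these compounds alone.

Series notes. In a functional assay on HeLa cells (Homo sapiens) for antiproliferative activity, read by MTT assay, with a stated time of 72 h (a lower number here means a stronger inhibitor, a higher number a weaker inhibitor), compound 1 `COc1ccc2occ(CSC(=S)N3CCCCC3)c(=O)c2c1` gives 3500 nM, compound 3 `CCOC(=O)c1cc(=O)c2cc(CSC(=S)N(C)c3ccccc3)ccc2o1` gives 18100 nM, and compound 2 `O=c1c(CSC(=S)N2CCCCC2)coc2cc(Cl)ccc12` gives 440 nM. Compound 2 stands lowest of the three numbers; its gap to compound 1 is beyond the scatter, and its gap to compound 3 is wider still, also beyond the scatter. Both other compounds differ from compound 2 in more than one place, so no single change in the set has been read on its own.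

Compound 4 `CC(C)N(C(=S)SCc1coc2cc(Cl)ccc2c1=O)C(C)C` differs from compound 2 by diisopropylamino in place of piperidin-1-yl on a thiocarbonyl carbon. For the measured compounds named here, no measured pair carries this change by itself, so its size is unknown from the data. The two groups are of similar make-up, and the change sits away from the part of the core that differs between compound 1 and compound 2, so a step in this assay no larger than the scatter is expected, with a slight weakening if anything. The step from compound 2 to compound 4 is therefore estimated at a 1.4-fold higher number from compound 2 to compound 4 (0.13 log units; within the scatter). For compound 4 the expected value in this assay is 600 nM, within a range of 200 nM to 2000 nM.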

Compound 4, half-maximal inhibitory concentration: > 25000 nM
Compound 4: no number, only a limit; the forecaster's own chance of this, stated with the estimate: 3%; middle value at least 41-fold (1.61 log units) from the limit.
By their numbers in this assay, from the lowest: compound 2; then compound 1; then compound 3. At a limit, above all of these: compound 4.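

In this assay compound 4 gives > 25000 nM, which is a limit of the assay and not a number: the limit of > 25000 nM in this assay, at which 1 of the 4 values shown sits. Diisopropylamino in place of piperidin-1-yl on a thiocarbonyl carbon is the first single change that can be read in the series, and it gives an at least 56-fold higher number from compound 2 to compound 4 (1.75 log units; beyond the scatter). This place is therefore not indifferent to the group it carries, since the shared remainder of compound 2 does not by itself keep the activity, and the true size of the step stays unfixed.

The compounds shown leave open whether the step follows from the loss of the ring or from the two isopropyl groups, a question that pyrrolidin-1-yl, morpholin-4-yl or diethylamino at the same place would help to settle. From the compounds shown here alone, whether the same change acts alike on the core of compound 1 also remains open.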